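The compounds below may be only part of what the source reports. "The series", "measured", "known", "first", "only" and "open" are said of these compounds alone.

Series so far, in a functional assay on HepG2 cells (Homo sapiens) for antiproliferative activity, read by XTT assay, with a stated time of 72 h; a lower number here means a stronger inhibitor, a higher number a weaker inhibitor:

- Compound 1 `Nc1nc(N)c2c(-c3ccsc3)cn([C@@H]3O[C@H](CO)[C@@H](O)[C@H]3O)c2n1`: > 20000 nM, a limit.
- Compound 2 `Cc1nc(N)c2c(-c3cccs3)cn([C@@H]3O[C@H](CO)[C@@H](O)[C@H]3O)c2n1`: > 20000 nM, a limit.
- Compound 3 `Cc1nc(N)c2c(-c3ccsc3)cn([C@@H]3O[C@H](CO)[C@@H](O)[C@H]3O)c2n1`: > 20000 nM, a limit.

Compound 3 therefore has no numerical value, only a limit. It shares this standing with the other two compounds: the limit of > 20000 nM in this assay, at which 3 of the 3 values shown sit. Among the compounds with values here, no compound in the set can be ranked against another in this assay.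

The next compound is compound 4 `C#Cc1cn([C@@H]2O[C@H](CO)[C@@H](O)[C@H]2O)c2nc(C)nc(N)c12`, with ethynyl in place of thiophen-3-yl on an aromatic carbon. Within the data shown here, two measured steps touch compound 3. One is a step that the two limits leave unreadable from compound 2 to compound 3, which changes the group at the same aromatic carbon as the new step. The other is a step that the two limits leave unreadable from compound 1 to compound 3, which lies elsewhere on the shared core. Neither gives a size, so neither supplies a magnitude or a direction to carry over to the ethynyl change.

The expectation rests only on the limit of compound 3 at > 20000 nM and on the absence of any measured number in the set. No step beyond the scatter is expected in this assay, although this is weakly founded, since the group that enters has not been tested here. The expected change is a number no higher from compound 3 to compound 4 (the limit leaves the size open). For compound 4 the estimated value is 20000 nM, with an expected range of 4000 nM to 40000 nM.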

Compound 4, half-maximal inhibitory concentration: > 20000 nM
Compound 4: a limit, no number (the forecaster's own chance of this, stated with the estimate: 65%); the middle value sits exactly at the limit.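

In this assay compound 4 gives > 20000 nM, which is a limit and not a number. Within the data shown here, no step from compound 2 or compound 3 to compound 4 can be read, and the series remains unranked: the limit of > 20000 nM in this assay, at which 4 of the 4 values shown sit. The compounds shown leave open whether any change at this aromatic carbon or elsewhere on the shared core gives a measurable value in this assay.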